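Adding Fluoro to a Compound Sitting at the Limit

The compounds below may be only part of what the source reports. "The series", "measured", "known", "first", "only" and "open" are said of these compounds alone.

Compound 1 `Cc1ccc2nc(Nc3ccnc(Nc4ccc(S(C)(=O)=O)cc4)n3)sc2c1` was tested in a functional assay on PC-3 cells (Homo sapiens) for antiproliferative activity, read by MTT assay, with a stated time of 48 h; a lower number here means a stronger inhibitor, a higher number a weaker inhibitor. In this assay compound 1 gives only a limit, > 50000 nM, so no real number for it is known. Two close relatives were measured alongside it. Compound 2 `CS(=O)(=O)c1ccc(Nc2nccc(Nc3nc4ccc(Cl)cc4s3)n2)cc1` carries chloro in place of methyl on an aromatic carbon; in this assay compound 2 likewise gives a limit, > 50000 nM. The pair yields a step that the two limits leave unreadable from compound 1 to compound 2. Compound 3 `Cc1ccc2nc(Nc3ccnc(Nc4ccc(S(N)(=O)=O)cc4)n3)sc2c1` carries amino in place of methyl on a sulfonyl sulfur, and in this assay compound 3 gives 1640 nM, which amounts to an at least 30-fold lower number from compound 1 to compound 3 (1.48 log units; beyond the scatter). Of the three compounds, two therefore sit at the limit of > 50000 nM in this assay, at which 2 of the 3 values shown sit, and only compound 3 produces a number.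

Compound 4 `Cc1ccc2nc(Nc3nc(Nc4ccc(S(C)(=O)=O)cc4)ncc3F)sc2c1` is not yet measured. It differs from compound 1 by fluoro in place of hydrogen on an aromatic carbon. Among the measured compounds shown here, neither measured step concerns a change at this place, and the single step that moves the number alters the sulfonyl group, which compound 4 keeps unchanged. For the measured compounds named here, no measured step therefore suggests that fluoro here would lift the compound off the limit. Compound 4 is expected to remain near it. The estimate for compound 4 is 60000 nM, within a range from 8000 nM to 300000 nM. That estimate corresponds to an expected step that the limit leaves unreadable from compound 1 to compound 4, with a limit again the most likely report.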

Compound 4, half-maximal inhibitory concentration: > 50000 nM
Compound 4: a limit, no number; the forecaster's own chance of this, stated with the estimate: 65%; the middle value lies beyond the limit too.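

In this assay compound 4 gives > 50000 nM, which is a limit and not a number. Compound 1 also gives only a limit, so the step between compound 1 and compound 4 cannot be read: the limit of > 50000 nM in this assay, at which 3 of the 4 values shown sit.

The compounds shown leave open whether fluoro in place of hydrogen changes the activity at all, and by how much.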